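Trifluoromethyl on Compound 1: An Expected Step

The source may hold more compounds than are shown below. What is called first, only, known or untested is meant among the compounds shown, and "the series" means these compounds.

Going by the values given here, in a functional assay on MDA-MB-435 cells (Homo sapiens) for cytotoxicity, read by sulforhodamine B assay, with a stated time of 48 h (on this read-out higher numbers stand for lower toxicity in this test and lower numbers for higher toxicity in this test), compound 1 `Nc1c(C(=O)Nc2ccccc2)sc2nc3c(cc12)CCCCCC3` gives 897 nM, the lowest of the two numbers so far, and compound 2 `Nc1c(C(=O)Nc2ccccc2Cl)sc2nc3c(cc12)CCCCCC3` gives 20900 nM. Compound 3 `Nc1c(C(=O)Nc2cccc(C(F)(F)F)c2)sc2nc3c(cc12)CCCCCC3` remains unmeasured. It carries trifluoromethyl in place of hydrogen on an aromatic carbon, meta to a large group: trifluoromethyl in place of hydrogen on an aromatic carbon. Among the compounds with values here, only one measured step bears on this change, chloro in place of hydrogen on an aromatic carbon, and it is large: a 23-fold higher number from compound 1 to compound 2 (1.37 log units; beyond the scatter). With a different group entering, a smaller step in the same direction is expected, towards a higher number. The estimated step is a 2.8-fold higher number from compound 1 to compound 3 (0.45 log units; beyond the scatter). The expected value for compound 3 is 2500 nM, within an estimated range of 600 nM to 12000 nM.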

Compound 3, concentration lethal to 50% of the cells: 59200 nM
Estimate against measurement, compound 3: 24-fold (1.37 log units) below; measured number above the stated range.
By their numbers in this assay, from the lowest: compound 1; then compound 2; then compound 3.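

In this assay, trifluoromethyl on an aromatic carbon, meta to a large group, brings a large change (a 66-fold higher number from compound 1 to compound 3 (1.82 log units; beyond the scatter)) towards lower toxicity in this test. A large rise is therefore not confined to chloro, and compound 1, which carries hydrogen, keeps the lowest number of the three. Nothing measured here bears on why this step is so large.

From the compounds shown here alone, whether methyl, an amine or a hydroxyl group at this place would also raise the number stays open. So does the outcome of trifluoromethyl on another carbon of this ring.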